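The source may hold more compounds than are shown below. What is called first, only, known or untested is meant among the compounds shown, and "the series" means these compounds.

In an assay on CHO cells for displacement of a labelled ligand from adenosine receptor A1 (Homo sapiens), read by scintillation counting, tested at 10 uM (on this read-out higher numbers stand for more inhibition at the one concentration tested (going by the name of the read-out) and lower numbers for less inhibition), compound 2 `CNC(=O)[C@@]12C[C@@H]1[C@@H](n1cnc3c(NCc4cccc(Cl)c4)nc(C#CCCCCc4cn(-c5cccc([N+](=O)[O-])c5)nn4)nc31)[C@H](O)[C@@H]2O` gives 8%, the second highest of the three numbers measured. Among the compounds with values here, compound 1 `CNC(=O)[C@@]12C[C@@H]1[C@@H](n1cnc3c(NCc4cccc(Cl)c4)nc(C#CCCCCc4cn(-c5ccc(C(=O)O)cc5)nn4)nc31)[C@H](O)[C@@H]2O` gives 0%, and the only change between them is a swap of the group on the aromatic nitrogen: a number 8 percentage points higher from compound 1 to compound 2 (within the scatter). Compound 3 `CNC(=O)[C@@]12C[C@@H]1[C@@H](n1cnc3c(NCc4cccc(Cl)c4)nc(C#CCCCc4cn(-c5cccc([N+](=O)[O-])c5)nn4)nc31)[C@H](O)[C@@H]2O` gives 10%, which sits within the scatter of compound 2. Compound 4 `CNC(=O)[C@@]12C[C@@H]1[C@@H](n1cnc3c(NCc4cccc(Cl)c4)nc(C#CCCCCc4cn(-c5ccc(N=C=S)cc5)nn4)nc31)[C@H](O)[C@@H]2O` has not yet been tested. It differs from compound 2 in one place: a group of 9 heavy atoms (7 carbon, 1 nitrogen, 1 sulfur; one six-membered aromatic ring of carbon only) in place of a group of 9 heavy atoms (6 carbon, 1 nitrogen, 2 oxygen; one six-membered aromatic ring of carbon only), on an aromatic nitrogen. Within the data shown here, the single measured step that bears on such a swap, from compound 1 to compound 2, stayed within the scatter, so no step beyond the scatter is expected here either. Compound 4 is therefore estimated at 8%, with a range from 0% to 20%. This expectation amounts to no change at the digits printed from compound 2 to compound 4 (within the scatter).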

Compound 4, a percentage reported as inhibition, at one concentration (the size of the read-out at that concentration, not a potency): 2%
Estimate against measurement, compound 4: 6 percentage points above; the range from low to high includes it.
By their numbers in this assay, from the lowest: compounds 1, 4, 2 and 3 (each within the scatter of the next).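

In this assay, the isothiocyanate-bearing phenyl group on the aromatic nitrogen gives a number 6 percentage points lower from compound 2 to compound 4 (within the scatter) when it replaces 3-nitrophenyl and a number 2 percentage points higher from compound 1 to compound 4 (within the scatter) when isothiocyanate replaces the carboxylic acid on the ring. Three different substituted phenyl groups at this position, in compounds 1, 2 and 4, are therefore now linked by steps that all stay within the scatter. Nothing available explains these small steps. As far as these compounds go, whether an aniline-type amine or a plain methyl group on that nitrogen would read differently stays open. So does the effect of a longer chain joining this ring to the shared core.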